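A Chloro Substituent Added to a Flat Series

This account rests on a few compounds, and the source may have more. Where it says the series, first, only, none or still open, it means among the compounds named here.

Three compounds have so far been measured in a functional assay on SW480 cells (Homo sapiens) for inhibition, read by CCK-8 assay, with a stated time of 72 h, tested at 20 uM; on this read-out higher numbers stand for more inhibition of growth at the one concentration tested and lower numbers for less inhibition of growth:

compound 1, `CC(C)(C)OC(=O)/C=C1/C(=O)Nc2ccccc21`: 78.1%
compound 2, `COc1ccc2c(c1)/C(=C\C(=O)OC(C)(C)C)C(=O)N2`: 78.7%
compound 3, `CC(C)(C)OC(=O)/C=C1/C(=O)Nc2ccc(OC(F)(F)F)cc21`: 77.8%

The three numbers lie on top of one another. The step of a number 0.6 percentage points higher from compound 1 to compound 2 (within the scatter) and the step of a number 0.3 percentage points lower from compound 1 to compound 3 (within the scatter) are both within the scatter, and so is a number 0.9 percentage points lower from compound 2 to compound 3 (within the scatter). On these numbers compound 1 is indistinguishable from either of the other two; nothing in this set separates a methoxy or a trifluoromethoxy group from hydrogen on the aromatic ring of the shared core.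

Compound 4, `CC(C)(C)OC(=O)/C=C1/C(=O)Nc2c(Cl)cccc21`, is not yet measured. It differs from compound 1 by chloro in place of hydrogen on an aromatic carbon. Within the data shown here, the steps that bear on it are the three aromatic substitutions already seen, each of which stayed within the scatter. None of them introduces a chlorine, and none of them puts a group at the place where the chlorine enters, so the comparison is indirect. Still, with every measured change on that ring leaving the read-out where it was, the expectation for compound 4 is a step of no size beyond the scatter, a number 0.1 percentage points lower from compound 1 to compound 4 (within the scatter). Compound 4 is therefore estimated at 78%, with a range from 66% to 88%.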

Compound 4, percent growth inhibition at one concentration: 78%
Estimate against measurement, compound 4: no gap at the digits printed, and the stated range covers the measured number.
By their numbers in this assay, from the lowest: compounds 3, 4, 1 and 2 (each within the scatter of the next).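

In this assay, chloro in place of hydrogen on an aromatic carbon, ortho to a fused ring and meta to a fused ring, gives a number 0.1 percentage points lower from compound 1 to compound 4 (within the scatter). This extends the flat picture in two ways: the earlier compounds showed only methoxy and trifluoromethoxy, both at another place on the ring, whereas compound 4 shows that a halogen at this new place also leaves the read-out within the scatter of compound 1, so that no aromatic substitution shown so far, at either place, separates a compound from the unsubstituted one. Nothing available explains why this single chlorine leaves the number unmoved, and the result alone gives no reason for it.

As far as these compounds go, it remains open whether a group of another kind at this place, such as an amine, a carboxylic acid or a longer alkyl chain, would move the number beyond the scatter. Every compound shown also keeps the tert-butyl ester and the amide hydrogen, so it remains equally open what a carboxylic acid in place of that ester, or a methyl group in place of that hydrogen, would do.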